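The compounds below may be only part of what the source reports. "The series", "measured", "known", "first", "only" and "open" are said of these compounds alone.

Three compounds have been measured in a functional assay on HepG2 cells (Homo sapiens) for antiproliferative activity, tested at 1 uM; on this read-out higher numbers stand for more inhibition at the one concentration tested (going by the name of the read-out) and lower numbers for less inhibition:

Compound 1, `COc1ccc(CO/N=C/c2c(C)nn(C)c2Oc2ccc(Cl)cc2)cc1`, gives 13.9%.
Compound 2, `Cc1ccc(CO/N=C/c2c(C)nn(C)c2Oc2ccc(Cl)cc2)cc1`, gives 31.3%.
Compound 3, `COC(=O)c1ccc(CO/N=C/c2c(C)nn(C)c2Oc2ccc(Cl)cc2)cc1`, gives 20.3%.

Compound 2 stands highest of the three; its nearest neighbour is compound 3, with a number 11 percentage points lower from compound 2 to compound 3 (beyond the scatter), and the furthest is compound 1, with a number 17.4 percentage points higher from compound 1 to compound 2 (beyond the scatter). The step of a number 6.4 percentage points higher from compound 1 to compound 3 (within the scatter) lies within the scatter.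

The unmeasured compound 4, `Cc1ccc(CO/N=C/c2c(C)nn(C)c2Oc2ccccc2)cc1`, is derived from compound 2 by a single change: hydrogen in place of chloro on an aromatic carbon. The 4-chlorophenoxy group of compound 2 becomes a phenoxy group.

None of the three measured steps bears on this change. All of them alter the substituent on the other aromatic ring, the one carrying the methyl, methoxy or methoxycarbonyl group, and leave the chloro untouched. The measured steps show that changes of a single aromatic substituent elsewhere in the molecule shift the read-out by modest amounts or not beyond the scatter, but they give no direction for the loss of a chloro. Going by the values given here, with no comparable pair available, the expectation for this assay is a step of no clear direction and not beyond the scatter, with a wide range to allow for a modest change either way.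

Compound 4 is therefore estimated at 25%, between 10% and 40%, which corresponds to an expected step of a number 6.3 percentage points lower from compound 2 to compound 4 (within the scatter).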

Compound 4, a percentage reported as inhibition, at one concentration (the size of the read-out at that concentration, not a potency): 8.4%
For compound 4 the middle estimate is 16.6 percentage points above the measured one; measured number below the stated range.
By their numbers in this assay, from the lowest: compounds 4, 1 and 3 (each within the scatter of the next, the first and the last beyond it); then compound 2.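

In this assay, the change from 4-chlorophenoxy to phenoxy gives a number 22.9 percentage points lower from compound 2 to compound 4 (beyond the scatter), the first step shown at a position that stayed the same across the earlier compounds. It shows that the read-out responds to this place on the molecule as well as to the methyl, methoxy or methoxycarbonyl group on the other aromatic ring, and that with methyl held in place, the compound carrying chloro reads higher than the one carrying hydrogen. Nothing measured here accounts for this step.

With only chloro and hydrogen shown at this place, it remains open whether the higher read-out is particular to chloro or would also appear with fluoro, bromo or trifluoromethyl there. As far as these compounds go, it is also open whether losing the chloro would give a step of similar size with methoxy or methoxycarbonyl on the other aromatic ring, and how an amine or a carboxylic acid on that ring would read with either the 4-chlorophenoxy or the phenoxy group.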